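This account rests on a few compounds, and the source may have more. Where it says the series, first, only, none or still open, it means among the compounds named here.

Measured in a functional assay on P388 cells (Mus musculus) for antiproliferative activity; a higher number here means a weaker inhibitor, a lower number a stronger inhibitor
- compound 1 `N#Cc1ccc(S(=O)(=O)Nc2cccc3c(Cl)c[nH]c23)cc1` gives 1.4 ug/mL
- compound 2 `Nc1ccc(S(=O)(=O)Nc2cccc3c(Cl)c[nH]c23)cc1` gives 0.81 ug/mL
- compound 3 `CS(=O)(=O)Nc1ccc(S(=O)(=O)Nc2cccc3c(Cl)c[nH]c23)cc1` gives 1.6 ug/mL

Compound 3 at 1.6 ug/mL stands level with the other two within the scatter. Compound 4 `CNS(=O)(=O)c1ccc(S(=O)(=O)Nc2cccc3c(Cl)c[nH]c23)cc1` has methylsulfamoyl in place of methanesulfonamido on an aromatic carbon, para to a large group (methylsulfamoyl in place of methanesulfonamido on an aromatic carbon). Three measured steps alter this same substituent (a 1.7-fold lower number from compound 1 to compound 2 (0.24 log units; within the scatter)) (a 1.1-fold higher number from compound 1 to compound 3 (0.06 log units; within the scatter)) (a 2.0-fold higher number from compound 2 to compound 3 (0.30 log units; within the scatter)) and all stay within the scatter. Among the measured compounds shown here, no measured compound carries methylsulfamoyl, so this read-across is indirect. No step beyond the scatter is expected in this assay for this change, and the estimated step is small (a 1.2-fold lower number from compound 3 to compound 4 (0.09 log units; within the scatter)). For compound 4 the expected value is 1.3 ug/mL (estimated range 0.6 ug/mL to 2.8 ug/mL).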

Compound 4, half-maximal inhibitory concentration: 0.9 ug/mL
The estimate for compound 4 lay 1.4-fold (0.16 log units) above the measured number, within the range that was stated.
By their numbers in this assay, from the lowest: compounds 2, 4, 1 and 3 (each within the scatter of the next).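

Replacing methanesulfonamido with methylsulfamoyl, the same atoms joined differently, on the aromatic carbon para to a large group gives a 1.8-fold lower number from compound 3 to compound 4 (0.25 log units; within the scatter) in this assay. The other two comparisons give a 1.1-fold higher number from compound 2 to compound 4 (0.05 log units; within the scatter) and a 1.6-fold lower number from compound 1 to compound 4 (0.19 log units; within the scatter) so methylsulfamoyl joins cyano, amino and methanesulfonamido in a set that this assay does not separate, and the orientation of the sulfonamide link shows no step beyond the scatter. From the compounds shown here alone, whether a carboxylic acid, a dimethylamino group or a longer chain on the sulfamoyl nitrogen would move the number beyond the scatter remains open. No supporting data bear on this flat response.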